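The source may hold more compounds than are shown below. What is called first, only, known or untested is meant among the compounds shown, and "the series" means these compounds.

In an ADME assay on LL24 cells (Homo sapiens) for inhibition, read by MTT assay, with a stated time of 24 h (a lower number here means a stronger inhibitor, a higher number a weaker inhibitor), compound 3 `N#Cc1ccc(C(=O)N/N=C/c2ccc([N+](=O)[O-])o2)cc1` stands at > 200000 nM which is a limit of the assay and not a number. Compound 1 `CCCCc1ccc(C(=O)N/N=C/c2ccc([N+](=O)[O-])o2)cc1` gives > 200000 nM which is likewise a limit. Compound 2 `CCCc1ccc(C(=O)N/N=C/c2ccc([N+](=O)[O-])o2)cc1` reads 89000 nM as a true number. Compound 4 `O=C(N/N=C/c1ccc([N+](=O)[O-])o1)c1ccc(Cl)cc1` has chloro in place of cyano on an aromatic carbon, para to a large group (chloro in place of cyano on an aromatic carbon). Within the data shown here, two measured steps touch this place: an at least 2.2-fold higher number from compound 2 to compound 3 (0.35 log units; beyond the scatter) for cyano in place of propyl and a step that the two limits leave unreadable from compound 1 to compound 3 for cyano in place of butyl. Neither replaces cyano with chloro, so the guide is weak. A modest move to a lower number is expected (an at least 1.6-fold lower number from compound 3 to compound 4 (0.22 log units; that floor lies within the scatter)), and a second limit reading remains quite possible. The estimate for compound 4 is 120000 nM with an expected range (from 45000 nM to 300000 nM).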

Compound 4, half-maximal inhibitory concentration: 187000 nM
Estimate against measurement, compound 4: 1.6-fold (0.19 log units) below, within the range that was stated.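

In this assay, chloro on this aromatic carbon gives a true number where cyano gave only a limit, and against propyl the result is a 2.1-fold higher number from compound 2 to compound 4 (0.32 log units; beyond the scatter). Against the other two groups only floors can be read, an at least 1.0-fold lower number from compound 3 to compound 4 (0.02 log units; that floor lies within the scatter) for cyano and an at least 1.0-fold lower number from compound 1 to compound 4 (0.02 log units; that floor lies within the scatter) for butyl, so the real size of both steps stays unknown. Limits still bound these comparisons: the limit of > 200000 nM in this assay, at which 2 of the 4 values shown sit.

As far as these compounds go, whether an amine or a carboxylic acid on this carbon would give a true number remains open. So does the reading for a chain shorter than propyl, such as ethyl.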